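The source may report more compounds than this note shows. Statements on the series, on what has been measured and on what is new or still open speak of the compounds shown alone.

Of the compounds shown here, three sharing one core have been measured in a physicochemical assay for solubility, read by HPLC, in phosphate buffer, measured as kinetic solubility, at pH 7.4; on this read-out lower numbers stand for lower solubility and higher numbers for higher solubility. Compound 1 `CCC(=O)c1cc(-c2ccc(S(N)(=O)=O)cc2)n(-c2ccc(Cl)cc2)n1` gives 41900 nM, the highest of the three. Compound 2 `CCC(=O)c1cc(-c2ccc(S(N)(=O)=O)cc2)n(-c2ccc(C(F)(F)F)cc2)n1` gives 7500 nM and compound 3 `CCC(=O)c1cc(-c2ccc(S(N)(=O)=O)cc2)n(-c2cccc(Cl)c2)n1` gives 6900 nM, two numbers within the scatter of each other. Compound 4 `CCC(=O)c1cc(-c2ccc(S(N)(=O)=O)cc2)n(-c2ccccc2)n1` has not yet been measured. It differs from compound 3 by one change: hydrogen in place of chloro on an aromatic carbon.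

Two measured steps alter the same chlorophenyl group. Trifluoromethyl in place of chloro on an aromatic carbon gave a 5.6-fold lower number from compound 1 to compound 2 (0.75 log units; beyond the scatter), and 3-chlorophenyl in place of 4-chlorophenyl on an aromatic nitrogen gave a 6.1-fold lower number from compound 1 to compound 3 (0.78 log units; beyond the scatter). Both are modest but beyond the scatter. Neither removes the chloro, so they offer a rough size and no firm direction. With compound 3 at 6900 nM, well under compound 1 at 41900 nM, a modest rise is expected rather than a drop. The estimated change is a 2.9-fold higher number from compound 3 to compound 4 (0.46 log units; beyond the scatter). For compound 4 the estimated value is 20000 nM, with an expected range from 8000 nM to 50000 nM.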

Compound 4, solubility: 47200 nM
Estimate against measurement, compound 4: 2.4-fold (0.37 log units) below; the range from low to high includes it.
By their numbers in this assay, from the lowest: compounds 3 and 2 (each within the scatter of the next); then compounds 1 and 4 (each within the scatter of the next).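

In this assay, hydrogen in place of chloro on the 3-chlorophenyl group gives a 6.8-fold higher number from compound 3 to compound 4 (0.84 log units; beyond the scatter) and hydrogen in place of trifluoromethyl gives a 6.3-fold higher number from compound 2 to compound 4 (0.80 log units; beyond the scatter), so plain phenyl stands well above both of these substituted compounds. Removing the chloro from the 4-chlorophenyl group is different, giving a 1.1-fold higher number from compound 1 to compound 4 (0.05 log units; within the scatter) and staying within the scatter, so among these compounds the effect of the chloro depends on where it sits on the ring, not merely on its presence. No measurement shown here offers an explanation for this difference.

Going by these compounds, only chloro, trifluoromethyl and hydrogen are compared on this ring, so what a methoxy group or an amine would do there remains open. The rest of the shared core stays fixed throughout, so whether the same pattern holds with another group elsewhere on it cannot be told.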